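Ring swap at the sulfonyl carbon: compound 2 to compound 4

The source may hold more compounds than are shown below. What is called first, only, known or untested is meant among the compounds shown, and "the series" means these compounds.

Measured so far:
- compound 1 `O=S(=O)(CC1=NCCO1)c1c(-c2ccc(Cl)cc2)nn(-c2ccccc2)c1-c1ccc(Cl)cc1`: "not active" (no number reported)
- compound 2 `Cc1ccc(C2CNN=C2S(=O)(=O)CC2=NCCS2)cc1`: 52.2%
- compound 3 `COc1ccc(-c2nn(-c3ccccc3)c(-c3ccc(C)cc3)c2S(=O)(=O)CC2=NCCO2)cc1`: 68.2%

In a functional assay, read by Griess assay, with a stated time of 150 min, tested at 100 ug/mL (a higher number here means a stronger effect of the compound at the concentration tested, a lower number a weaker effect), compound 1 is reported as "not active" (no number reported), with no number given. Compound 2 gives 52.2% in this assay, the lowest of the two numbers reported; its nearest neighbour, compound 3, gives 68.2%, which lies beyond the scatter above it. For the measured compounds named here, compound 3 and compound 1 share neither the core of compound 2 nor its ring on the sulfonyl-bound carbon, so no step from a measured pair matches the change to be judged.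

Compound 4 `Cc1ccc(C2CNN=C2S(=O)(=O)CC2=NCCO2)cc1` is not yet measured. It differs from compound 2 by a group of 5 heavy atoms (3 carbon, 1 nitrogen, 1 oxygen; one five-membered non-aromatic ring with 2 hetero atoms) in place of a group of 5 heavy atoms (3 carbon, 1 nitrogen, 1 sulfur; one five-membered non-aromatic ring with 2 hetero atoms), on a saturated chain carbon bound to a sulfonyl sulfur. The closest measured hint is that compound 3 and compound 1 both carry this entering ring and sit at opposite ends of the range, which gives no direction. For compound 4 in this assay no step beyond the scatter is expected, so a number 2.8 percentage points higher from compound 2 to compound 4 (within the scatter) is the expected step. Compound 4 is therefore estimated at 55%, within 35% to 75%.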

Compound 4, a percentage reported as activity, at one concentration (the size of the read-out at that concentration, not a potency): 51.4%
Beside the measured number, compound 4's estimate is 3.6 percentage points above it; measured number inside the range.
By their numbers in this assay, from the lowest: compounds 4 and 2 (each within the scatter of the next); then compound 3.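

In this assay, the exchange of one five-membered non-aromatic ring for the other, on a saturated chain carbon bound to a sulfonyl sulfur, gives a number 0.8 percentage points lower from compound 2 to compound 4 (within the scatter). For the compounds shown here, this is the first step read directly at this place, and on the core shared by compound 2 and compound 4 the read-out does not tell the sulfur-containing ring from the oxygen-containing ring. No supporting data bear on why the two rings read alike.

Still open, from the compounds shown here alone, is whether a carboxylic acid or a primary amine at this place, in place of either ring, would give a step beyond the scatter. Also open, going by these compounds, is whether the two rings would read alike on the core of compound 1 or the core of compound 3.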